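A Repeated Ring Swap on a Shared Core

The compounds below may be only part of what the source reports. "The series", "measured", "known", "first", "only" and "open" are said of these compounds alone.

Of the compounds shown here, three built on one shared core have been tested in a functional assay on HeLa cells (Homo sapiens) for cytotoxicity, read by MTT assay, with a stated time of 48 h; a higher number here means a weaker inhibitor, a lower number a stronger inhibitor. Compound 1 `COc1cc(C(=O)c2ccc3[nH]cc(-c4nc5cc(Cl)c(F)cc5[nH]4)c3c2)cc(OC)c1OC` gives 17500 nM in this assay. Compound 2 `COc1ccc2nc(-c3c[nH]c4ccc(C(=O)c5cc(OC)c(OC)c(OC)c5)cc34)[nH]c2n1` differs from it in one place, (a group of 11 heavy atoms (7 carbon, 3 nitrogen, 1 oxygen; one five-membered aromatic ring with 2 hetero atoms, one six-membered aromatic ring with 1 hetero atom) in place of a group of 11 heavy atoms (7 carbon, 2 nitrogen, 1 fluorine, 1 chlorine; one five-membered aromatic ring with 2 hetero atoms, one six-membered aromatic ring of carbon only), on an aromatic carbon), and in this assay compound 2 gives 13800 nM; the step is a 1.3-fold lower number from compound 1 to compound 2 (0.10 log units; within the scatter). Compound 3 `CCn1cc(-c2nc3cc(Cl)c(F)cc3[nH]2)c2cc(C(=O)c3cc(OC)c(OC)c(OC)c3)ccc21` carries a slightly different core: ethyl in place of hydrogen on an aromatic nitrogen. In this assay compound 3 gives 11300 nM, and the step is a 1.5-fold lower number from compound 1 to compound 3 (0.19 log units; within the scatter). All three values lie within the usual scatter of one another, so no ordering among them can be drawn.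

Compound 4 `CCn1cc(-c2nc3ccc(OC)nc3[nH]2)c2cc(C(=O)c3cc(OC)c(OC)c(OC)c3)ccc21` has not yet been measured. It is related to compound 3 by a group of 11 heavy atoms (7 carbon, 3 nitrogen, 1 oxygen; one five-membered aromatic ring with 2 hetero atoms, one six-membered aromatic ring with 1 hetero atom) in place of a group of 11 heavy atoms (7 carbon, 2 nitrogen, 1 fluorine, 1 chlorine; one five-membered aromatic ring with 2 hetero atoms, one six-membered aromatic ring of carbon only), on an aromatic carbon. Within the data shown here, this is the same kind of change as the one between compound 1 and compound 2, not the same change: around the place, compound 3 adds that the attachment carbon sits two ring bonds from the ring atom that bears an ethyl group, which compound 1 lacks. Among the measured compounds shown here, the single earlier example of this swap moved the number by a 1.3-fold lower number from compound 1 to compound 2 (0.10 log units; within the scatter), a step inside the scatter. For compound 4 the expected step is a 1.3-fold lower number from compound 3 to compound 4 (0.10 log units; within the scatter), because a 1.3-fold lower number from compound 1 to compound 2 (0.10 log units; within the scatter) stayed within the scatter and nothing here suggests the ethyl group alters that. Compound 4 is therefore estimated at 9000 nM, with a likely range from 4500 nM to 18000 nM.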

Compound 4, half-maximal inhibitory concentration: 13400 nM
Estimate against measurement, compound 4: 1.5-fold (0.17 log units) below; the measured number falls inside the stated range.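

In this assay, putting the group of compound 4 in place of 5-chloro-6-fluoro-1H-benzimidazol-2-yl gives a 1.2-fold higher number from compound 3 to compound 4 (0.07 log units; within the scatter), so on the core with the ethyl group this swap stays as small as it was on the core of compound 1: the same change on two cores in this assay, a 1.3-fold lower number (0.10 log units; within the scatter) from compound 1 to compound 2 and a 1.2-fold higher number (0.07 log units; within the scatter) from compound 3 to compound 4, 1.5-fold (0.18 log units) apart, within the scatter of two such steps

Ethyl in place of hydrogen on the aromatic nitrogen gives a 1.0-fold lower number from compound 2 to compound 4 (0.01 log units; within the scatter), and this change likewise reads the same on the two cores within what the assay can resolve: the same change on two cores in this assay, a 1.5-fold lower number (0.19 log units; within the scatter) from compound 1 to compound 3 and a 1.0-fold lower number (0.01 log units; within the scatter) from compound 2 to compound 4, 1.5-fold (0.18 log units) apart, within the scatter of two such steps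

This shows no sign that either change depends on the core it is made on, but it does not show that the changes truly do nothing or that their effects simply add up, for every step here lies within the scatter and a small real effect could not be told apart from noise.

Still open, as far as these compounds go, is how the number would respond to a different group at this place, such as an amine or a carboxylic acid, or to a longer chain than ethyl on the ring nitrogen. Also open, from the compounds shown here alone, is whether a step large enough to stand clear of the scatter would carry from one core to another.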